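A few compounds are considered here, and "the series" means these few. Any claim that something is new, unique, unknown or untested is made for them only; others in the source may bear on it.

Notes on the series, all read in a functional assay on MCF7 cells (Homo sapiens) for antiproliferative activity, read by XTT assay, with a stated time of 72 h (a higher number here means a weaker inhibitor, a lower number a stronger inhibitor), as the common measure. Compound 1 (`COc1ccc(-c2cc3ccccc3nc2/C=C/C(=O)c2ccccc2)cc1`) gives 4040 nM here, and compound 2 (`COc1ccc(C(=O)/C=C/c2nc3ccccc3cc2-c2ccc(OC)cc2)cc1`) gives 7380 nM here. Among the measured compounds shown here, these are the only two numbers so far, and they lie within the scatter of each other, so compound 2 holds no firm rank.

The next compound is compound 3 (`COc1ccc(-c2cc3ccccc3nc2/C=C/C(=O)c2ccc(OC)c(OC)c2)cc1`). It differs from compound 2 by methoxy in place of hydrogen on an aromatic carbon and the change is methoxy in place of hydrogen on an aromatic carbon, which turns 4-methoxyphenyl to 3,4-dimethoxyphenyl. For the measured compounds named here, the one measured step of the same kind is a 1.8-fold higher number from compound 1 to compound 2 (0.26 log units; within the scatter) and it falls on the same ring. That is a single step and thin evidence, but it gives no ground for a large shift. No step beyond the scatter is therefore expected in this assay and neither direction is favoured. The estimated step reads a 1.1-fold lower number from compound 2 to compound 3 (0.06 log units; within the scatter) as a working figure. For compound 3 the estimated value is 6500 nM with a wide expected range (2500 nM to 17000 nM).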

Compound 3, half-maximal inhibitory concentration: 6030 nM
The estimate for compound 3 lay 1.1-fold (0.03 log units) above the measured number, within the range that was stated.
By their numbers in this assay, from the lowest: compounds 1, 3 and 2 (each within the scatter of the next).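

In this assay, a second methoxy on this aromatic ring, ortho to a methoxy group and meta to a large group, turns 4-methoxyphenyl to 3,4-dimethoxyphenyl and reads a 1.2-fold lower number from compound 2 to compound 3 (0.09 log units; within the scatter). Among the compounds shown here, measured against the plain ring, 3,4-dimethoxyphenyl in place of phenyl on the carbonyl carbon reads a 1.5-fold higher number from compound 1 to compound 3 (0.17 log units; within the scatter), so phenyl, 4-methoxyphenyl and 3,4-dimethoxyphenyl at this place now form a set of three with no step beyond the scatter, where the earlier pair gave only a single step. No measured property bears on this result, so the data give no account of it.

The compounds shown leave open whether any group on this ring can move the number beyond the scatter, since hydrogen and methoxy are the only substituents seen there, and an amine, a carboxylic acid or a longer chain such as butoxy would put that to the test. Also open, as far as these compounds go, is the part of the molecule that stays the same in compounds 1, 2 and 3, including the 4-methoxyphenyl group on the shared core, so the effect of changing that group cannot be read from this set.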